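This account rests on a few compounds, and the source may have more. Where it says the series, first, only, none or still open, it means among the compounds named here.

Measured compounds:
compound 1, `Cc1cc(CN2C(=O)C(C3=NS(=O)(=O)c4cc(NS(C)(=O)=O)ccc4N3)=C(O)[C@H]3CCC[C@H]32)ccc1F` — > 1000 nM
compound 2, `CS(=O)(=O)Nc1ccc2c(c1)S(=O)(=O)N=C(C1=C(O)C3CCCC3N(c3ccccc3)C1=O)N2` — "not determined" (no result reported)

The study concerns a shared core carrying a cyclic sulfonamide and a fused bicyclic lactam, tested in an ADME assay on Huh-7 cells (Homo sapiens) for cytotoxicity, with a stated time of 72 h; a lower number here means that less compound is tolerated, a higher number that more compound is tolerated. Compound 1, `Cc1cc(CN2C(=O)C(C3=NS(=O)(=O)c4cc(NS(C)(=O)=O)ccc4N3)=C(O)[C@H]3CCC[C@H]32)ccc1F`, gives > 1000 nM in this assay, and this is a limit of the assay rather than a number. Compound 2, `CS(=O)(=O)Nc1ccc2c(c1)S(=O)(=O)N=C(C1=C(O)C3CCCC3N(c3ccccc3)C1=O)N2`, has no result in this assay. Where compound 1 stands can therefore be said only in outline: the one value it has sits at the limit of > 1000 nM in this assay, at which 1 of the 2 values shown sits, and the other entry carries no number at all, so no step between measured compounds is available.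

Compound 3, `CS(=O)(=O)Nc1ccc2c(c1)S(=O)(=O)N=C(C1=C(O)[C@H]3CCC[C@H]3N(CC3CC3)C1=O)N2`, differs from compound 1 at a single place: cyclopropyl in place of 4-fluoro-3-methylphenyl on a saturated chain carbon bound to an amide-type nitrogen in a ring. Among the compounds with values here, with no measured step to lean on, the expectation for this assay is a step from compound 1 to compound 3 of no size beyond the scatter, in either direction, and most probably a second value that again only reaches the limit of the assay. Compound 3 is thus expected to give 3000 nM, within a range from 800 nM to 20000 nM. The step that the limit leaves unreadable from compound 1 to compound 3 is estimated to be small.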

Compound 3, half-maximal cytotoxic concentration: > 33000 nM
Compound 3 ended at the assay's limit; the forecaster's own chance of this, stated with the estimate: 80%; middle value at least 11-fold (1.04 log units) from the limit.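

In this assay compound 1 gives > 1000 nM, a limit of the assay and not a number. Within the data shown here, compound 3 gives > 33000 nM, also a limit, so no step between compound 1 and compound 3 can be read. The compounds shown leave open whether cyclopropyl in place of 4-fluoro-3-methylphenyl changes the tolerated concentration at all.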